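A Smaller Ring on the Amide Carbonyl

This account rests on a few compounds, and the source may have more. Where it says the series, first, only, none or still open, it means among the compounds named here.

Compound 1 `CCCC(=O)N1CCC(NS(=O)(=O)c2ccc(NC(=O)C3CCCCC3)c3ccccc23)CC1` and compound 2 `CCCC(=O)N1CCC(NS(=O)(=O)c2ccc(NC(=O)c3ccc(C(C)(C)C)cc3)c3ccccc23)CC1` share the same core and differ only in the group attached to the amide carbonyl carbon. In an in vitro functional assay on CHO/Galpha16 cells for antagonist activity at C-C chemokine receptor type 8 (Homo sapiens), read by FLIPR (a higher number here means a weaker inhibitor, a lower number a stronger inhibitor), compound 1 gives 6.1 nM, and compound 2 gives 6.9 nM. Among the measured compounds shown here, the single measured step of a 1.1-fold higher number from compound 1 to compound 2 (0.05 log units; within the scatter) lies within the scatter, so compound 2 stands level with compound 1 in this assay, and neither can be called the stronger inhibitor on these two numbers. Compound 3 `CCCC(=O)N1CCC(NS(=O)(=O)c2ccc(NC(=O)C3CCC3)c3ccccc23)CC1` carries the change (cyclobutyl in place of 4-(tert-butyl)phenyl on a carbonyl carbon). For the measured compounds named here, the one measured step bears on it only indirectly: it exchanged one ring for another without consequence, whereas the present change takes away much more of the group, and no measured step covers such a cut. A modest loss of inhibition is therefore expected, amounting to the step of a 2.2-fold higher number from compound 2 to compound 3 (0.34 log units; beyond the scatter). Compound 3 is expected to give 15 nM, within a range from 4 nM to 60 nM.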

Compound 3, half-maximal inhibitory concentration: 57.9 nM
Beside the measured number, compound 3's estimate is 3.9-fold (0.59 log units) below it; measured number inside the range.
By their numbers in this assay, from the lowest: compounds 1 and 2 (each within the scatter of the next); then compound 3.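

Compound 3 shows that this position does not accept every ring alike: the earlier exchange of cyclohexyl for 4-(tert-butyl)phenyl on the carbonyl carbon gave no change beyond the scatter, but the smaller group does. In this assay, cyclobutyl in place of 4-(tert-butyl)phenyl gives an 8.4-fold higher number from compound 2 to compound 3 (0.92 log units; beyond the scatter), and cyclobutyl in place of cyclohexyl gives a 9.5-fold higher number from compound 1 to compound 3 (0.98 log units; beyond the scatter), so among these three compounds the aromatic and the non-aromatic six-membered rings stand level and only the four-membered ring stands apart. No measurement at hand accounts for this loss of inhibition.

The compounds shown leave open how the number moves with a cyclopentyl group on the carbonyl carbon, and whether an open chain such as butyl behaves like the rings. They also leave open what an amine or a carboxylic acid on the ring would do.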